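Methoxy to Hydroxy: What to Expect for Compound 3

The source may hold more compounds than are shown below. What is called first, only, known or untested is meant among the compounds shown, and "the series" means these compounds.

In a functional assay on DU-145 cells (Homo sapiens) for inhibition, read by sulforhodamine B assay, with a stated time of 48 h (a lower number here means a stronger inhibitor of growth, a higher number a weaker inhibitor of growth), compound 2 `COc1cc(-c2nn(-c3cccc(NC(=O)Nc4cc(C(F)(F)F)cc(C(F)(F)F)c4)c3)cc2-c2ccncc2)ccc1Cl` gives 1310 nM and stands at the low end of the two numbers recorded, while compound 1 `O=C(Nc1cccc(-n2cc(-c3ccncc3)c(-c3ccc(Cl)c(O)c3)n2)c1)Nc1cccc(C(F)(F)F)c1` gives 1760 nM, a gap that lies within the scatter of this kind of test. Compound 3 `O=C(Nc1cccc(-n2cc(-c3ccncc3)c(-c3ccc(Cl)c(O)c3)n2)c1)Nc1cc(C(F)(F)F)cc(C(F)(F)F)c1` differs from compound 2 in one place: hydrogen in place of methyl on an oxygen on an aromatic ring. Among the measured compounds shown here, no measured pair isolates this change, and the two values at hand sit close together, so no step beyond the scatter is expected in this assay. For compound 3 the expected step is a 1.1-fold lower number from compound 2 to compound 3 (0.04 log units; within the scatter). Compound 3 is estimated at 1200 nM, with a likely range from 500 nM to 3000 nM.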

Compound 3, concentration for 50% growth inhibition: 1250 nM
For compound 3 the middle estimate is 1.0-fold (0.02 log units) below the measured one, and the stated range covers the measured number.
By their numbers in this assay, from the lowest: compounds 3, 2 and 1 (each within the scatter of the next).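

Methoxy to hydroxy gives a 1.0-fold lower number from compound 2 to compound 3 (0.02 log units; within the scatter) in this assay and so, on this pair alone, the oxygen on the aromatic ring can carry either methyl or hydrogen with no difference beyond the scatter. Trifluoromethyl in place of hydrogen on an aromatic carbon gives a 1.4-fold lower number from compound 1 to compound 3 (0.15 log units; within the scatter) and likewise leaves the number within the scatter. No supporting data bear on either result. Still open, as far as these compounds go, is whether a longer chain on that oxygen, or an amine in its place, would shift growth inhibition beyond the scatter.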